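The source may report more compounds than this note shows. Statements on the series, on what has been measured and on what is new or still open speak of the compounds shown alone.

Compound 3 `N#CN/C(=N\C1CCCCC1)Nc1cccnc1` is one of three close relatives that share a common core and differ only in the group carried on a double-bonded nitrogen. In a functional assay on the whole organism (blood, strain Wistar-Okamoto) with Rattus norvegicus as the target, with a stated time of 5 days (a higher number here means that more compound is needed for the effect, a lower number that less compound is needed), compound 3 gives 20 mg/kg. Compound 2 `CCC(CC)/N=C(\NC#N)Nc1cccnc1` gives 20 mg/kg in this assay, and compound 1 `CC(C)/N=C(\NC#N)Nc1cccnc1` gives 2.5 mg/kg. Compound 3 therefore stands level with compound 2, the two together forming the high end of the three numbers, while compound 1 sits well apart: an 8.0-fold higher number from compound 1 to compound 3 (0.90 log units; beyond the scatter), and no change at the digits printed from compound 2 to compound 3 (within the scatter).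

Compound 4 `N#CN/C(=N\Cc1ccco1)Nc1cccnc1` has not been measured in this assay. It differs from compound 3 in a single place: (furan-2-yl)methyl in place of cyclohexyl on a double-bonded nitrogen.

Among the measured compounds shown here, two measured steps touch this position. The step of an 8.0-fold higher number from compound 1 to compound 2 (0.90 log units; beyond the scatter) and the step of an 8.0-fold higher number from compound 1 to compound 3 (0.90 log units; beyond the scatter) both show that replacing isopropyl with a larger group raised the number, whereas no change at the digits printed from compound 2 to compound 3 (within the scatter) shows that pentan-3-yl and cyclohexyl gave the same number. For the measured compounds named here, no measured step puts an aromatic ring or an oxygen at this position, so the direction of the present change is open. The step expected in this assay is a 2.0-fold lower number from compound 3 to compound 4 (0.30 log units; within the scatter), most likely within the scatter, with room for a somewhat lower number. For compound 4 the expected value in this assay is 10 mg/kg, within a range of 2.5 mg/kg to 40 mg/kg.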

Compound 4, minimum effective dose: 20 mg/kg
Beside the measured number, compound 4's estimate is 2.0-fold (0.30 log units) below it, and the stated range covers the measured number.
By their numbers in this assay, from the lowest: compound 1; then compounds 2, 3 and 4 (each within the scatter of the next).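

In this assay, among the compounds shown here, the step of no change at the digits printed from compound 3 to compound 4 (within the scatter) and the step of no change at the digits printed from compound 2 to compound 4 (within the scatter) show that (furan-2-yl)methyl, the first group at this position with a five-membered aromatic ring and an oxygen, stands with the carbon-only cyclohexyl and pentan-3-yl groups. The step of an 8.0-fold higher number from compound 1 to compound 4 (0.90 log units; beyond the scatter) places this new group as far from isopropyl as the other two, so among these four compounds isopropyl alone is set apart, and swapping a ring of carbon only for an aromatic ring with one hydrogen-bond acceptor leaves the number unmoved at this position. No measurement is at hand that would explain why these three different groups give the same number.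

It remains open whether compound 1 marks a real optimum at isopropyl, since the compounds shown do not say how methyl, ethyl or tert-butyl on the double-bonded nitrogen would read in this assay. Nor do they settle whether a phenyl or benzyl group, or a chain ending in an amine or a carboxylic acid, would stay level with compound 3 or come closer to compound 1.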